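This account rests on a few compounds, and the source may have more. Where it says the series, first, only, none or still open, it means among the compounds named here.

Of the compounds shown here, three share one core and have been measured in an in vitro ADME assay on the whole organism (microsomes, liver, Mus musculus) for metabolic stability, read by LC-MS, with a stated time of 24 h, at a dose of 5 mg/kg by the intravenous route; a higher number here means that the compound lasts longer, a lower number that the compound disappears faster. Compound 1 `O=[N+]([O-])c1cn2c(n1)OC[C@@H](NCc1ccc(OC(F)(F)F)c(Cl)c1)C2` gives 0.223 h in this assay. Compound 2 `CN(Cc1ccc(OC(F)(F)F)cc1)[C@@H]1COc2nc([N+](=O)[O-])cn2C1`, which carries a methyl on the amine nitrogen and no substituent beside the trifluoromethoxy group, gives 0.183 h in this assay. Compound 3 `O=[N+]([O-])c1cn2c(n1)OC[C@@H](NCc1ccc(OC(F)(F)F)cc1F)C2` gives 0.242 h in this assay. Compound 3 has the highest of the three numbers, but its gap to compound 1 and its gap to compound 2 both fall within the scatter of repeated measurements, so no ranking among the three is supported; all three sit at a short half-life.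

Compound 4 `O=[N+]([O-])c1cn2c(n1)OC[C@@H](NCc1ccc(OC(F)(F)F)cc1Oc1ccccc1)C2` has not yet been measured in this assay. It differs from compound 3 in one place: phenoxy in place of fluoro on an aromatic carbon. Within the data shown here, no measured pair shows a step of this kind, so nothing here tells how such a change moves the half-life. With every measured compound clustered closely, the working expectation is that the step from compound 3 to compound 4 is about a 1.3-fold lower number from compound 3 to compound 4 (0.13 log units; within the scatter), that is, no change beyond the scatter, with a slightly lower number somewhat more likely than a higher one. Compound 4 is therefore estimated at 0.18 h in this assay, within a range of 0.08 h to 0.4 h.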

Compound 4, half-life: 0.107 h
The estimate for compound 4 lay 1.7-fold (0.23 log units) above the measured number, within the range that was stated.
By their numbers in this assay, from the lowest: compounds 4, 2, 1 and 3 (each within the scatter of the next, the first and the last beyond it).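

In this assay, phenoxy in place of fluoro, on an aromatic carbon ortho to a large group and meta to a trifluoromethoxy group, gives a 2.3-fold lower number from compound 3 to compound 4 (0.35 log units; beyond the scatter). Among these compounds, the earlier compounds offered no pair differing in one place, so this is the first sign that the half-life responds to what this aromatic carbon carries, and here the response is downward, with 7 heavy atoms and a six-membered aromatic ring entering where 1 heavy atom leaves. No measurement bearing on why the half-life falls with this change is available, so the step stands as an observation only.

On these data alone, a single pair cannot separate the contribution of the ether oxygen from that of the added aromatic ring, so it remains open how a methoxy group, a benzyl group, a directly attached phenyl ring or a chlorine at this carbon would compare with fluoro and phenoxy. As far as these compounds go, it also remains open whether the same change would move the half-life similarly on a compound with a methyl on the amine nitrogen, or whether an amine or a carboxylic acid on the added phenyl ring would alter the step.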